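Swapping a prenyl ether for a fluorobenzyl ether

This account rests on a few compounds, and the source may have more. Where it says the series, first, only, none or still open, it means among the compounds named here.

The shared core of compound 1 `CCC1(Cc2ccccc2)OS(=O)(=O)C=C1OC`, compound 2 `CCC1(Cc2ccccc2)OS(=O)(=O)C=C1OCCCc1ccccc1` and compound 3 `CCC1(Cc2ccccc2)OS(=O)(=O)C=C1OCC=C(C)C` was tested in an ADME assay on HEL cells (Homo sapiens) for cytotoxicity, with a stated time of 3 days; on this read-out lower numbers stand for higher toxicity in this test and higher numbers for lower toxicity in this test. Compound 3 is the only one of the three with a number: in this assay compound 3 gives 400000 nM. For compound 1 the result is a limit, > 400000 nM. For compound 2 the result is likewise a limit, >= 20000 nM. Accordingly, the step from compound 1 to compound 3 reads a number no higher from compound 1 to compound 3 (the limit leaves the size open), the step from compound 2 to compound 3 reads a step that the limit leaves unreadable from compound 2 to compound 3, and the step from compound 1 to compound 2 reads a step that the two limits leave unreadable from compound 1 to compound 2; none of them has a readable size, because the limit of > 400000 nM in this assay, at which 1 of the 3 values shown sits, and the limit of >= 20000 nM in this assay, at which 1 of the 3 values shown sits, cap what can be seen.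

Compound 4 `CCC1(Cc2ccccc2)OS(=O)(=O)C=C1OCc1ccc(F)cc1` differs from compound 3 in one place: 4-fluorophenyl in place of 2-methylprop-1-en-1-yl on a saturated chain carbon bound to an oxygen on an unsaturated carbon. For the measured compounds named here, the steps that bear on it, those involving compound 2 and compound 3, give no measurable size, so no change beyond the usual scatter can be argued for in either direction; the step from compound 3 to compound 4 is expected to be a 2.0-fold lower number from compound 3 to compound 4 (0.30 log units; within the scatter). Compound 4 is therefore estimated at 200000 nM, with a range from 50000 nM to 400000 nM, and a good chance that this assay again returns only a limit.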

Compound 4, minimum cytotoxic concentration: >= 50000 nM
Compound 4: a limit, no number; the forecaster's own chance of this, stated with the estimate: 60%; the middle value is on the limit's open side.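

In this assay compound 4 gives >= 50000 nM, which is a limit and not a number. Its steps from compound 1, compound 2 and compound 3 therefore cannot be read: the limit of >= 50000 nM in this assay, at which 1 of the 4 values shown sits.

The compounds shown leave open whether any of these ether groups changes the minimum cytotoxic concentration at all.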